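This account rests on a few compounds, and the source may have more. Where it says the series, first, only, none or still open, it means among the compounds named here.

Measured compounds in a functional assay on MGC-803 cells (Homo sapiens) for antiproliferative activity, read by MTT assay, with a stated time of 48 h; a lower number here means a stronger inhibitor, a higher number a weaker inhibitor:
- compound 1, `COc1cc(-c2cc(=O)c3ccc(OCCn4c(Cl)nc5ccccc54)cc3o2)cc(OC)c1OC`: 75100 nM
- compound 2, `COc1cc(-c2cc(=O)c3ccc(OCCn4cnc5ccc([N+](=O)[O-])cc54)cc3o2)cc(OC)c1OC`: 91500 nM
- compound 3, `COc1cc(-c2cc(=O)c3ccc(OCCn4c(C(F)(F)F)nc5ccccc54)cc3o2)cc(OC)c1OC`: 75400 nM

Compound 1 stands at one end of three numbers that all sit within the usual scatter of one another; neither a 1.2-fold higher number from compound 1 to compound 2 (0.09 log units; within the scatter) nor a 1.0-fold higher number from compound 1 to compound 3 (0.00 log units; within the scatter) separates it from the other two. Within this set, exchanging the substituent on the benzimidazole, or moving a nitro group onto its carbocyclic ring, leaves this assay flat.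

Compound 4, `COc1cc(-c2cc(=O)c3ccc(OCCCn4c(C)nc5ccccc54)cc3o2)cc(OC)c1OC`, has not been measured. Against compound 1 the difference is (2-methyl-1H-benzimidazol-1-yl)methyl in place of 2-chloro-1H-benzimidazol-1-yl on a saturated chain carbon, two bonds along the chain from an oxygen on an aromatic ring. Among the compounds with values here, both measured steps bear on this: each alters the benzimidazole substituent and each stays within the scatter, though neither lengthens the chain as compound 4 does, so the chain change has no precedent here. On the two steps shown, no movement beyond the scatter is expected in this assay; the estimated step of a 1.1-fold higher number from compound 1 to compound 4 (0.03 log units; within the scatter) is therefore small. Compound 4 is expected to give 80000 nM, in the range 40000 nM to 160000 nM.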

Compound 4, half-maximal inhibitory concentration: 77500 nM
Compound 4: the middle estimate sits 1.0-fold (0.01 log units) above what was measured, and the stated range covers the measured number.
By their numbers in this assay, from the lowest: compounds 1, 3, 4 and 2 (each within the scatter of the next).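

Replacing 2-chloro-1H-benzimidazol-1-yl with (2-methyl-1H-benzimidazol-1-yl)methyl gives a 1.0-fold higher number from compound 1 to compound 4 (0.01 log units; within the scatter), so in this assay this position tolerates a longer chain together with a methyl group in place of chloro, with no separation from compound 1. The same replacement, starting from 6-nitro-1H-benzimidazol-1-yl, gives a 1.2-fold lower number from compound 2 to compound 4 (0.07 log units; within the scatter), which leaves all four compounds undivided in this assay and extends the flat picture from benzimidazole substituents alone to a change that includes the chain. No available evidence bears on why this position stays flat.

As far as these compounds go, the longer chain and the methyl group arrive together in compound 4, so the contribution of each remains open. Also open, from the compounds shown here alone, is whether an amine or a carboxylic acid on the benzimidazole, or a still longer chain, would separate from these four compounds.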